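This account rests on a few compounds, and the source may have more. Where it says the series, first, only, none or still open, it means among the compounds named here.

Measured so far:
compound 1, `CC(C)(C)c1ccc(C(=O)NCc2ccc(OC(F)(F)F)cc2)cc1`, 160 nM;
compound 2, `O=C(O)c1ccc(CNC(=O)c2ccc(-c3ccccc3)cc2)cc1`, 440 nM.

In an assay on HeLa cells with Bile acid receptor (Homo sapiens) as the target, read by a luciferase reporter, with a stated time of 24 h (a higher number here means that more compound is needed for the effect, a lower number that less compound is needed), compound 1 gives the lower of the two numbers, and compound 2 gives a number that lies beyond the scatter above it. No step between measured compounds that differ in one place exists, so nothing of a single change is yet shown. Compound 3, `CC(C)(C)c1ccc(C(=O)NCc2ccc(-c3nnn[nH]3)cc2)cc1`, differs from compound 1 by 1H-tetrazol-5-yl in place of trifluoromethoxy on an aromatic carbon. The step is expected to be small, a 1.6-fold higher number from compound 1 to compound 3 (0.19 log units; within the scatter), within or only just beyond the scatter. Compound 3 is expected to give 250 nM, between 80 nM and 800 nM.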

Compound 3, half-maximal effective concentration: 120 nM
Beside the measured number, compound 3's estimate is 2.1-fold (0.32 log units) above it, and the stated range covers the measured number.
By their numbers in this assay, from the lowest: compounds 3 and 1 (each within the scatter of the next); then compound 2.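

On an aromatic carbon para to a large group, 1H-tetrazol-5-yl in place of trifluoromethoxy gives a 1.3-fold lower number from compound 1 to compound 3 (0.12 log units; within the scatter) in this assay and so leaves the number within the scatter. This position therefore reads the same with a group that has no ring and no hydrogen-bond donor as with a five-membered aromatic ring that has 1 hydrogen-bond donor. Nothing given here bears on why the two groups read alike. As far as these compounds go, whether a carboxylic acid or an amine at this position would also read the same remains open.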